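The compounds below may be only part of what the source reports. "The series", "measured", "known", "first", "only" and "open" are said of these compounds alone.

Compound 1 `O=C(Cn1c(=O)c(Cc2ccccc2)nc2ccccc21)N/N=C/c1ccccc1` and compound 2 `O=C(Cn1c(=O)c(Cc2ccccc2)nc2ccccc21)N/N=C/c1ccc([N+](=O)[O-])cc1` share one core and differ only in one group. In an assay for inhibition of Amine oxidase [flavin-containing] A (Bos taurus), read by fluorescence, with a stated time of 60 min (on this read-out lower numbers stand for stronger inhibition and higher numbers for weaker inhibition), compound 1 gives 3.1 nM, while compound 2 gives 98 nM, the highest of the two numbers; the change is a 32-fold higher number from compound 1 to compound 2 (1.50 log units; beyond the scatter). Compound 3 `O=C(Cn1c(=O)c(Cc2ccccc2)nc2ccccc21)N/N=C1/C(=O)Nc2ccccc21` carries a group of 11 heavy atoms (8 carbon, 2 nitrogen, 1 oxygen; one five-membered non-aromatic ring with 1 hetero atom, one six-membered aromatic ring of carbon only) in place of a group of 11 heavy atoms (7 carbon, 2 nitrogen, 2 oxygen; one six-membered aromatic ring of carbon only), on an amide-type nitrogen. Within the data shown here, no measured step tests this exact swap; the only step in hand concerns the nitro group, which compound 3 no longer carries. A step of a 3.3-fold lower number from compound 2 to compound 3 (0.51 log units; beyond the scatter) is therefore expected for compound 3. Compound 3 is estimated at 30 nM, with a range from 5 nM to 200 nM.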

Compound 3, half-maximal inhibitory concentration: 7.3 nM
Compound 3: the middle estimate sits 4.1-fold (0.61 log units) above what was measured; measured number inside the range.
By their numbers in this assay, from the lowest: compound 1; then compound 3; then compound 2.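

In this assay, the group on the amide-type nitrogen need not be a single aromatic ring: the group with a five-membered non-aromatic ring and a six-membered aromatic ring gives a 13-fold lower number from compound 2 to compound 3 (1.13 log units; beyond the scatter). Even so, it does not fully match the plain ring, with a 2.4-fold higher number from compound 1 to compound 3 (0.37 log units; beyond the scatter). Nothing available explains either step. From the compounds shown here alone, it remains open what an amine or a methoxy group would do in place of the nitro group, and how a chlorine on the six-membered aromatic ring of compound 3 would change its number.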